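The source may report more compounds than this note shows. Statements on the series, on what has been measured and on what is new or still open speak of the compounds shown alone.

Three compounds share one core and differ only in the small saturated ring attached to the chain carbon that also carries the aromatic ring. Compound 1 `c1ccc(C(/N=C2\CCCCCN2)C2CC2)cc1` carries a cyclopropyl there; in a functional assay on the whole organism (plasma, strain Sprague-Dawley) with Rattus norvegicus as the target, with a stated time of 2 h, at a dose of 100 mg/kg by the oral route (a higher number here means a stronger effect of the compound at the dose given, a lower number a weaker effect), compound 1 gives 51%. Compound 2 `c1ccc(C(/N=C2\CCCCCN2)C2CCC2)cc1` carries a cyclobutyl, and in this assay compound 2 gives 44%. Compound 3 `c1ccc(C(/N=C2\CCCCCN2)C2CCCC2)cc1` carries a cyclopentyl, and in this assay compound 3 gives 46%. Among these three numbers compound 1 has the highest, but the steps of a number 7 percentage points lower from compound 1 to compound 2 (within the scatter) and a number 5 percentage points lower from compound 1 to compound 3 (within the scatter) both lie within the scatter, as does a number 2 percentage points higher from compound 2 to compound 3 (within the scatter), so nothing separates the three compounds in this assay.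

Compound 4 `c1csc(C(/N=C2\CCCCCN2)C2CC2)c1` keeps the cyclopropyl of compound 1 and changes the aromatic ring instead: thiophen-2-yl in place of phenyl on a saturated chain carbon bound to a double-bonded nitrogen and a saturated ring carbon. For the measured compounds named here, none of the measured steps touches this aromatic ring; all three vary the saturated ring alone, and all three stayed within the scatter. Going by the values given here, there is therefore no measured step that bears on the change from compound 1 to compound 4, and the only guide is that the series so far has tolerated small changes without a shift beyond the scatter.

On that basis the expected step of a number 3 percentage points lower from compound 1 to compound 4 (within the scatter) is one of no change beyond the scatter, and compound 4 is estimated to give 48% in this assay, within a range from 30% to 65%.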

Compound 4, a percentage reported as inhibition, in the whole organism at one dose (the size of the read-out at that dose, not a potency): 44%
For compound 4 the middle estimate is 4 percentage points above the measured one, within the range that was stated.
By their numbers in this assay, from the lowest: compounds 2, 4, 3 and 1 (each within the scatter of the next).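

For the compounds shown here, until now only the saturated ring had varied, so this is the first look at the aromatic ring, on the saturated chain carbon bound to a double-bonded nitrogen and a saturated ring carbon. In this assay the change to thiophen-2-yl gives a number 7 percentage points lower from compound 1 to compound 4 (within the scatter) and so does not separate the two compounds: a five-membered aromatic ring with 1 hetero atom can stand in for a six-membered aromatic ring of carbon only without a shift beyond the usual scatter of this read-out at this one dose. No measured property is available that bears on this result, so the size of the step remains unexplained.

As far as these compounds go, whether a pyridin-2-yl ring, or a phenyl ring carrying a chlorine atom or a methoxy group, would move the number beyond the scatter remains open, and so does the effect of an amine or a carboxylic acid on the aromatic ring. It is also open whether thiophen-2-yl would behave the same way alongside cyclobutyl or cyclopentyl, and a single-dose read-out cannot show whether any of these compounds differ in potency.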